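A few compounds are considered here, and "the series" means these few. Any claim that something is new, unique, unknown or untested is made for them only; others in the source may bear on it.

Working notes on the series. Compound 3 `O=C(O)[C@H](CO)NC(=O)[C@H]1C[C@@H](O)CN1` stands in an ADME assay on liver (Mus musculus, strain C57BL/6) for metabolic stability, read by HPLC, with a stated time of 12 h (a lower number here means that the compound disappears faster, a higher number that the compound lasts longer), at a limit of the assay, giving > 12 h and no number. Compound 2 `O=C(N[C@H](CO)C(=O)O)[C@@H]1C[C@H](O)CN1` also sits at a limit there, giving > 12 h. Compound 1 `O=C(N[C@H](CO)C(=O)O)[C@@H]1C[C@@H](O)CN1` gives 0.32 h, the only plain number shown. The steps seen are an at least 37-fold higher number from compound 1 to compound 2 (1.57 log units; beyond the scatter) and an at least 37-fold higher number from compound 1 to compound 3 (1.57 log units; beyond the scatter), both large, each resting on the fact that compounds 1 and 2 differ only in the configuration as drawn and (the fact that compounds 1 and 3 differ only in the configuration as drawn); the step that the two limits leave unreadable from compound 2 to compound 3 cannot be read, given (the limit of > 12 h in this assay, at which 2 of the 3 values shown sit).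

Compound 4 `O=C(O)[C@H](CO)NC(=O)[C@@H]1C[C@H](O)CN1` differs from compound 3 only in configuration: the two compounds have the same atoms and bonds and differ only in configuration as drawn: 2 of 3 stereo elements differ; a stereocentre at a saturated ring carbon is drawn R in compound 3 and S in compound 4; a stereocentre at a saturated ring carbon is drawn R in compound 3 and S in compound 4. Every inversion of ring configuration seen so far moved this assay by a large amount, so a large step is expected in either direction, and the estimate for compound 4 is 4 h, spanning 0.4 h to 12 h, which would be a step of an at least 3.0-fold lower number from compound 3 to compound 4 (0.47 log units; beyond the scatter).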

Compound 4, half-life: 0.51 h
Compound 4: middle estimate off by 7.8-fold (0.89 log units), on the high side, within the range that was stated.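

In (this assay) the chain stereocentre alone now carries a large step (an at least 23-fold lower number from compound 2 to compound 4 (1.37 log units; beyond the scatter)), whereas the earlier single-centre step lay at a ring carbon. Inverting both ring stereocentres also gives a large step (an at least 23-fold lower number from compound 3 to compound 4 (1.37 log units; beyond the scatter)), so no single stereocentre decides the read-out across the series. Compound 4 sits with compound 1 rather than with compound 3, although compounds 1 and 4 differ at two stereocentres (a 1.6-fold higher number from compound 1 to compound 4 (0.20 log units; within the scatter)).

Still open, from the compounds shown here alone, is whether these configuration effects persist with a methyl ether in place of the ring hydroxyl, or an ester in place of the carboxylic acid.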